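Swapping the Aryl Tail of Compound 2

The compounds below may be only part of what the source reports. "The series", "measured", "known", "first", "only" and "open" are said of these compounds alone.

Of the compounds shown here, three have been measured in a functional assay on HEK293 cells for antagonist activity at cysteinyl leukotriene receptor 2 (Homo sapiens), read by fluorescence and calcium flux, with stated times of 30 min and 1 h; on this read-out higher numbers stand for weaker inhibition and lower numbers for stronger inhibition. Compound 1 `Cc1c(F)cccc1CCCCOc1ccc(/C=C/c2cccc3c(CCCC(=O)O)c(C)n(CC(=O)O)c23)cc1` gives 7.2 nM, compound 2 `Cc1c(F)cccc1CCCCOc1ccc(/C=C/c2cccc3c(CCCC(=O)O)cn(CC(=O)O)c23)cc1` gives 14 nM, and compound 3 `Cc1c(Cl)cccc1CCCCOc1ccc(C#Cc2cccc3c(CC(=O)O)c(C)n(CC(=O)O)c23)cc1` gives 0.89 nM. Compound 2 therefore carries the highest of the three numbers: its nearest neighbour is compound 1, and the step of a 1.9-fold higher number from compound 1 to compound 2 (0.29 log units; within the scatter) lies within the scatter, while compound 3 stands furthest off, with a lower number whose gap to compound 2 exceeds the scatter.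

Compound 4 `O=C(O)CCCc1cn(CC(=O)O)c2c(/C=C/c3ccc(OCCCCc4c(F)ccc(F)c4F)cc3)cccc12` keeps everything of compound 2 except the aryl tail: 2,3,6-trifluorophenyl in place of 3-fluoro-2-methylphenyl on a saturated chain carbon, four bonds along the chain from an oxygen on an aromatic ring. Among the measured compounds shown here, none of the measured steps touches this part of the molecule. For the measured compounds named here, the only single-point step available, from compound 1 to compound 2, concerns a methyl on the shared core and stays within the scatter. Compound 3 differs from compound 2 in several places at once, so its lower number cannot be traced to any one change. With nothing in hand that bears on the tail, the expectation in this assay is a step of no change at the digits printed from compound 2 to compound 4 (within the scatter) that does not leave the scatter. Compound 4 is accordingly estimated at 14 nM, with a range from 5 nM to 40 nM.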

Compound 4, half-maximal inhibitory concentration in the cysteinyl leukotriene receptor 2 assay: 2.1 nM
For compound 4 the middle estimate is 6.7-fold (0.82 log units) above the measured one, and the stated range ends above it.
By their numbers in the cysteinyl leukotriene receptor 2 assay, from the lowest: compound 3; then compound 4; then compounds 1 and 2 (each within the scatter of the next).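

In the cysteinyl leukotriene receptor 2 assay the exchange of 3-fluoro-2-methylphenyl for 2,3,6-trifluorophenyl gives a 6.7-fold lower number from compound 2 to compound 4 (0.82 log units; beyond the scatter), which is the only step shown that touches the aryl tail and the only single change that goes beyond the scatter. The tail on the saturated chain carbon, four bonds along the chain from an oxygen on an aromatic ring, is therefore a place where the cysteinyl leukotriene receptor 2 assay responds to the aryl group, whereas a 1.9-fold higher number from compound 1 to compound 2 (0.29 log units; within the scatter), on the shared core, stays within the scatter. In a physicochemical assay for permeability, using PAMPA, with a stated time of 4 h, at pH 7.4, tested at 50 uM (on this read-out lower numbers stand for lower permeability and higher numbers for higher permeability), compound 2 gives < 0.05 10^-6 cm/s, which is a limit of the assay. In the physicochemical assay compound 4 gives < 0.05 10^-6 cm/s, which is also a limit of the assay. In the physicochemical assay the same change cannot be read, as both compounds sit at a limit of the assay: the limit of < 0.05 10^-6 cm/s in the physicochemical assay, at which 2 of the 2 values shown sit.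

The change removes a methyl and adds fluorines in one move, so the compounds shown do not separate which part of it goes with the lower number, and they give no reason for the step. As far as these compounds go, it also remains open how a tail carrying a chlorine, a methoxy or a trifluoromethyl group would read at this place, and whether the step from this tail change carries over to the cores of compound 1 and compound 3.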